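This account rests on a few compounds, and the source may have more. Where it says the series, first, only, none or still open, it means among the compounds named here.

Measured compounds:
Compound 1, `O=C(NCc1ccccc1Br)N1C(=O)c2ccccc2S1(=O)=O` — in a physicochemical assay for pharmacokinetics (a higher number here means that the compound lasts longer, a lower number that the compound disappears faster), compound 1 gives 0.253 h.
Compound 2, `O=C(NCc1ccccc1C(F)(F)F)N1C(=O)c2ccccc2S1(=O)=O` — in this assay compound 2 gives 0.187 h.
Compound 3, `O=C(OCc1ccccc1)N1C(=O)c2ccccc2S1(=O)=O` — in this assay compound 3 gives < 0.0167 h, which is a limit of the assay and not a number.

Among the two numbers shown, compound 1 stands highest, with compound 2 nearest, though the two sit within the scatter of each other. For compound 3 the assay reports only a limit. Compound 4, `COc1cccc(CNC(=O)N2C(=O)c3ccccc3S2(=O)=O)c1`, has not yet been measured in this assay. It differs from compound 1 in one place: 3-methoxyphenyl in place of 2-bromophenyl on a saturated chain carbon bound to an amide-type nitrogen. For the measured compounds named here, only one measured step bears on a change of the group carried by that aromatic ring: a 1.4-fold lower number from compound 1 to compound 2 (0.13 log units; within the scatter). That step exchanged one aromatic substituent for another while the rest of the molecule stayed the same, and it moved the number by less than the scatter. Compound 3 differs from compound 1 elsewhere, so the limit of < 0.0167 h in this assay, at which 1 of the 3 values shown sits, says nothing about the aromatic substituent. On this basis compound 4 is expected to land close to compound 1, and a 1.3-fold lower number from compound 1 to compound 4 (0.10 log units; within the scatter) is expected to be small, with no step beyond the scatter foreseen in either direction. The estimate for compound 4 in this assay is 0.2 h, with a range from 0.07 h to 0.55 h.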

Compound 4, half-life: 0.523 h
Compound 4: the middle estimate sits 2.6-fold (0.42 log units) below what was measured, within the range that was stated.
By their numbers in this assay, from the lowest: compounds 2 and 1 (each within the scatter of the next); then compound 4. At a limit, below all of these: compound 3.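

Setting 3-methoxyphenyl in place of 2-bromophenyl on a saturated chain carbon bound to an amide-type nitrogen gave, in this assay, a 2.1-fold higher number from compound 1 to compound 4 (0.32 log units; beyond the scatter) and thus the first step at this place to pass the scatter, though only modestly, whereas a 1.4-fold lower number from compound 1 to compound 2 (0.13 log units; within the scatter) had stayed within it. The group on this chain carbon can therefore move the half-life measurably while the core of compound 1 stays unchanged, so the earlier step did not show the full sensitivity of this place. Nothing measured among these compounds accounts for the step, and the reason for it stays unknown.

The single step changes both the substituent and the name of the aromatic group's substitution, from 2-bromophenyl to 3-methoxyphenyl, so the compounds shown cannot tell which of the two matters, and 2-methoxyphenyl and 3-bromophenyl would separate them. They also leave open how the half-life would respond to an amine or a carboxylic acid on the aromatic ring, or to a longer chain in place of the saturated chain carbon.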